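From 3-methylthiophen-2-yl to 4-(dimethylamino)phenyl

The compounds below may be only part of what the source reports. "The series", "measured", "known", "first", "only" and "open" are said of these compounds alone.

Within the data shown here, in a functional assay on DU-145 cells (Homo sapiens) for inhibition, read by trypan blue exclusion, with a stated time of 96 h (on this read-out lower numbers stand for stronger inhibition of growth and higher numbers for weaker inhibition of growth), compound 1 `Cc1ccsc1/C=C(/SCc1ccc(Cl)c(Cl)c1)C(=O)c1ccc(Cl)cc1` gives 50000 nM, the higher of the two numbers so far, while compound 2 `Cc1ccc(CS/C(=C/c2sccc2C)C(=O)c2ccc(Cl)cc2)cc1` gives 10000 nM. Compound 3 `CN(C)c1ccc(/C=C(/SCc2ccc(Cl)c(Cl)c2)C(=O)c2ccc(Cl)cc2)cc1` has 4-(dimethylamino)phenyl in place of 3-methylthiophen-2-yl on a double-bonded chain carbon bound to a double-bonded chain carbon. Among the measured compounds shown here, no measured step involves this place, so the only guide is the size of a 5.0-fold lower number from compound 1 to compound 2 (0.70 log units; beyond the scatter), a modest change made elsewhere. A similarly modest move toward a lower number in this assay is expected, with the expected step being a 3.3-fold lower number from compound 1 to compound 3 (0.52 log units; beyond the scatter). For compound 3 the estimated value is 15000 nM, with an expected range from 3000 nM to 50000 nM.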

Compound 3, concentration for 50% growth inhibition: 50000 nM
The estimate for compound 3 lay 3.3-fold (0.52 log units) below the measured number; the measured number falls inside the stated range.
By their numbers in this assay, from the lowest: compound 2; then compounds 1 and 3 (each within the scatter of the next).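

At this position, the first change examined on a double-bonded chain carbon bound to a double-bonded chain carbon, 4-(dimethylamino)phenyl in place of 3-methylthiophen-2-yl gives no change at the digits printed from compound 1 to compound 3 (within the scatter) in this assay. The swap from a five-membered sulfur-containing aromatic ring to a six-membered all-carbon one therefore leaves the read-out unmoved, unlike the earlier step on the saturated chain carbon bound to a sulfur. No available evidence bears on the reason for this result. Going by these compounds, it remains open whether an unsubstituted phenyl or a carboxylic acid on this carbon would shift the number, and whether 4-methylphenyl on the sulfur side would lower it with 4-(dimethylamino)phenyl in place.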